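The compounds below may be only part of what the source reports. "The series", "measured", "known", "first", "only" and "open" are said of these compounds alone.

Three compounds share one core with a methyl group on it and differ at the acid or amide and at the remote aryl ring. In an assay on isolated protein for inhibition of 2-Hydroxyacid oxidase 2 (Homo sapiens), tested at 1 uM (a lower number here means a weaker effect, a higher number a stronger effect of the compound at the concentration tested), compound 1 `Cc1n[nH]c(C(=O)O)c1Cc1cccc(-c2ccc(OC(F)(F)F)cc2)c1` gives 6%; compound 3 `Cc1n[nH]c(C(=O)O)c1Cc1cccc(-c2ccc(C(N)=O)cc2)c1` gives 18%; compound 2 `Cc1n[nH]c(C(N)=O)c1Cc1cccc(-c2ccc(F)cc2)c1` gives 1%. For the measured compounds named here, the only step within the set that changes one place is a number 12 percentage points higher from compound 1 to compound 3 (beyond the scatter). The number for compound 2 is the lowest of the three: compound 1 stands within the scatter of it, compound 3 beyond it.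

Compound 4 `CNC(=O)c1[nH]nc(C)c1Cc1cccc(-c2ccc(F)cc2)c1` is not yet measured. It differs from compound 2 by methyl in place of hydrogen on an amide-type nitrogen. No measured step touches the amide-type nitrogen; the one step shown moves a group on the aryl ring, so it does not bear directly on this change, and the carbamoyl of compound 2 already sits at the bottom of the set. In this assay no step beyond the scatter is therefore expected, and for compound 4 the estimate is 2% with a range of -8% to 12%, which means an expected step of a number 1 percentage points higher from compound 2 to compound 4 (within the scatter).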

Compound 4, a percentage reported as inhibition, at one concentration (the size of the read-out at that concentration, not a potency): 7%
For compound 4 the middle estimate is 5 percentage points below the measured one; the range from low to high includes it.
By their numbers in this assay, from the lowest: compounds 2, 1 and 4 (each within the scatter of the next); then compound 3.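

Methyl in place of hydrogen on an amide-type nitrogen gives, in this assay, a number 6 percentage points higher from compound 2 to compound 4 (within the scatter), so this first look at the amide-type nitrogen shows no step beyond the scatter for this change. With compound 2 at 1% and compound 4 at 7%, both read-outs are small at the single concentration tested, so a loss from this change would have little room to appear, and no gain can be claimed. Nothing available explains the result.

On these data alone, whether an ethyl group, a longer chain or a second methyl on this nitrogen would give a step beyond the scatter remains open. Also open, as far as these compounds go, is whether the methylcarbamoyl keeps this behaviour when the remote aryl ring carries a group other than fluorine, such as a nitrile.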